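This account rests on a few compounds, and the source may have more. Where it says the series, first, only, none or still open, it means among the compounds named here.

Compound 2 `Cc1cc2c(c(Oc3cccc(NS(=O)(=O)c4ccc(Cl)cc4)c3)n1)C(=O)N(C)C2=O` stands highest of the three numbers in a functional assay on HEK293 cells for agonist activity at Glucose-dependent insulinotropic receptor (Homo sapiens), read by cAMP accumulation, with a stated time of 30 min; a higher number here means a larger maximal response, a lower number a smaller maximal response: compound 2 gives 122%. Compound 3 `Cc1cc2c(c(Oc3cccc(NS(=O)(=O)c4ccc(Cl)cc4)c3)n1)C(=O)N(C(C)C)C2=O` gives 99% in this assay, and compound 1 `COc1cc2c(c(Oc3cccc(NS(=O)(=O)c4ccc(Cl)cc4)c3)n1)C(=O)N(C1CC1)C2=O` gives 97%. Compound 4 `Cc1cc2c(c(Oc3cccc(NS(=O)(=O)c4ccc(Cl)cc4)c3)n1)C(=O)N(C1CCCC1)C2=O` differs from compound 2 by cyclopentyl in place of methyl on an amide-type nitrogen in a ring. For the measured compounds named here, the one measured step that bears on this change is the one in which another larger group replaced the methyl on the amide-type nitrogen in a ring: a number 23 percentage points lower from compound 2 to compound 3 (beyond the scatter). The comparison with compound 1 mixes two changes and is set aside. Compound 4 is therefore expected to show a downward step of similar size, a number 24 percentage points lower from compound 2 to compound 4 (beyond the scatter). Compound 4 is estimated at 98%, within a range from 80% to 118%.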

Compound 4, largest response reached (reported as efficacy), in percent of the reference or control that the assay uses: 95%
Compound 4: middle estimate off by 3 percentage points, on the high side; low and high end bracket the measured number.
By their numbers in this assay, from the lowest: compounds 4, 1 and 3 (each within the scatter of the next); then compound 2.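

In this assay, a second larger group on the amide-type nitrogen in a ring brings a drop like that seen with isopropyl (a number 27 percentage points lower from compound 2 to compound 4 (beyond the scatter)). Cyclopentyl in place of isopropyl, which adds a five-membered non-aromatic ring of carbon only, shifts the response no further (a number 4 percentage points lower from compound 3 to compound 4 (within the scatter)), so among these three compounds methyl alone stands apart. Nothing available explains this behaviour. Ethyl, a longer chain, or a group carrying an amine or a carboxylic acid on this nitrogen remains open. So does whether any of them would match compound 2 or the pair of compound 3 and compound 4.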